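Benzyl ester to carboxylic acid on a purine amide series

The source may report more compounds than this note shows. Statements on the series, on what has been measured and on what is new or still open speak of the compounds shown alone.

Measured so far:
compound 1, `NCCCC[C@H](NC(=O)CN(c1nc(Cl)nc2[nH]cnc12)C1CC1)C(=O)OCc1ccccc1`, 11.4%
compound 2, `O=C(CN(c1nc(Cl)nc2[nH]cnc12)C1CC1)NCC(=O)OCc1ccccc1`, 14.6%

The series is tested in a functional assay on the whole organism (Tail, strain ICR) with Mus musculus as the target, in the tail flick test, with a stated time of 120 min, at a dose of 12.5 umol/kg by the oral route; a lower number here means a weaker effect, a higher number a stronger effect of the compound at the dose given. Compound 1 gives the lowest of the two numbers; its nearest neighbour is compound 2, and the step of a number 3.2 percentage points higher from compound 1 to compound 2 (within the scatter) is within the scatter, so the two values are not ordered. That step concerns hydrogen in place of 4-aminobutyl on a saturated chain carbon bound to an amide-type nitrogen and a carbonyl carbon.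

Compound 3, `NCCCC[C@H](NC(=O)CN(c1nc(Cl)nc2[nH]cnc12)C1CC1)C(=O)O`, differs from compound 1 at another place: hydrogen in place of benzyl on an oxygen next to a carbonyl group. Among the compounds with values here, no measured step touches the benzyl or the oxygen next to the carbonyl group, so nothing measured bears directly on this change. Within the data shown here, the only step known, from compound 1 to compound 2, is within the scatter, and both values are low. For compound 3 in this assay the step of a number 0.6 percentage points higher from compound 1 to compound 3 (within the scatter) is expected to stay within the scatter, with no direction assigned. Compound 3 is therefore estimated at 12%, with a range from 2% to 25%.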

Compound 3, a percentage reported as activity, at one dose (the size of the read-out at that dose, not a potency): 9.79%
Compound 3: the middle estimate sits 2.2 percentage points above what was measured; the range from low to high includes it.
By their numbers in this assay, from the lowest: compounds 3, 1 and 2 (each within the scatter of the next).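

The benzyl ester position now has a reading: in this assay the step of a number 1.6 percentage points lower from compound 1 to compound 3 (within the scatter) places hydrogen for benzyl on an oxygen next to a carbonyl group, so the change from benzyloxycarbonyl to carboxy gives no difference that can be separated at this dose. Neither of the two changes seen so far, at the 4-aminobutyl chain or at the benzyl, separates the compounds in this read-out. No measured evidence bears on this result.

Open, as far as these compounds go, are other groups on this oxygen, such as methyl or ethyl, and a primary amide in place of the carboxylic acid. Also open, from the compounds shown here alone, is how hydrogen in place of benzyl reads on compound 2, which carries hydrogen in place of 4-aminobutyl.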